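A few compounds are considered here, and "the series" means these few. Any claim that something is new, unique, unknown or untested is made for them only; others in the source may bear on it.

Series notes, cytotoxicity arm. In an ADME assay on HEK293-A cells (Homo sapiens) for cytotoxicity, read by MTT assay, with a stated time of 48 h (a lower number here means a stronger inhibitor, a higher number a weaker inhibitor), compound 1, `O=C1CNC(=O)N1C[C@H]1CN(c2ccc(-n3cc(-c4ccccn4)cn3)c(F)c2)C(=O)O1`, gives > 400 ug/mL, which is a limit of the assay and not a number. Compound 2, `CC(=O)OC[C@H]1CN(c2ccc(-n3cc(-c4ccccn4)cn3)c(F)c2)C(=O)O1`, gives > 400 ug/mL, again a limit. Compound 3, `O=CNC[C@H]1CN(c2ccc(-n3cc(-c4ccccn4)cn3)c(F)c2)C(=O)O1`, gives > 400 ug/mL, also a limit. Compound 2 thus stands on the limit alongside the other two measured compounds; (the limit of > 400 ug/mL in this assay, at which 3 of the 3 values shown sit). The measured steps are a step that the two limits leave unreadable from compound 1 to compound 2, a step that the two limits leave unreadable from compound 1 to compound 3 and a step that the two limits leave unreadable from compound 2 to compound 3, none of them readable because each end sits on the limit.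

Compound 4, `CONC(=O)[C@H]1CN(c2ccc(-n3cc(-c4ccccn4)cn3)c(F)c2)C(=O)O1`, is the next member. Relative to compound 2 the change is methoxycarbamoyl in place of acetoxymethyl on a saturated ring carbon. Among the compounds with values here, no measured step touches the ring carbon at which this change sits, and every measured variation on the chain left the read-out at the limit. The only expectation the data support is that compound 4 will again sit at or beyond the limit in this assay, with no step beyond the scatter in either direction. The expected step from compound 2 is a step that the limit leaves unreadable from compound 2 to compound 4. Compound 4 is accordingly estimated at 500 ug/mL, within a range of 250 ug/mL to 1000 ug/mL.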

Compound 4, half-maximal inhibitory concentration: > 400 ug/mL
Compound 4 was reported as a limit; the forecaster's own chance of this, stated with the estimate: 85%; the middle value lies beyond the limit too.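

In this assay compound 4 gives > 400 ug/mL, a limit of the assay and not a number. Its steps from compound 1, compound 2 and compound 3 cannot be read, because both ends of each sit on a limit: the limit of > 400 ug/mL in this assay, at which 4 of the 4 values shown sit.

The compounds shown leave open whether any of these changes on the saturated ring carbon shifts the read-out at all.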